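A few compounds are considered here, and "the series" means these few. Any claim that something is new, unique, unknown or untested is made for them only; others in the source may bear on it.

Compounds measured in a functional assay on HCT-116 cells (Homo sapiens) for antiproliferative activity, read by MTT assay, with a stated time of 72 h; on this read-out lower numbers stand for stronger inhibition and higher numbers for weaker inhibition:
compound 1, `Cc1ccc(Oc2c(/C=N\OCc3c(Cl)c(-c4ccc(F)cc4)nn3C)c(C)nn2C)cc1`: 2910 nM
compound 2, `COc1ccc(Oc2c(/C=N\OCc3c(Cl)c(-c4ccc(F)cc4)nn3C)c(C)nn2C)cc1`: 1180 nM
compound 3, `Cc1nn(C)c(Oc2ccc(F)cc2)c1/C=N\OCc1c(Cl)c(-c2ccc(Cl)cc2)nn1C`: 7250 nM

Compound 3 stands at the highest number of the three, beyond the scatter from both compound 1 and compound 2. Compound 4, `Cc1nn(C)c(Oc2ccc(OC(F)(F)F)cc2)c1/C=N\OCc1c(Cl)c(-c2ccc(Cl)cc2)nn1C`, differs from compound 3 in one place: trifluoromethoxy in place of fluoro on an aromatic carbon, on an aromatic carbon of a six-membered aromatic ring of carbon only, para to a large group. Going by the values given here, one measured step bears on this kind of change, a swap of a small group at the same place on the same ring: a 2.5-fold lower number from compound 1 to compound 2 (0.39 log units; beyond the scatter). Trifluoromethoxy has not been tested in any measured pair, so the expectation is a modest step toward a lower number, no larger than that one. For compound 4 the estimate in this assay is 4500 nM, between 1500 nM and 13500 nM. That estimate amounts to an expected step of a 1.6-fold lower number from compound 3 to compound 4 (0.21 log units; within the scatter).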

Compound 4, half-maximal inhibitory concentration: 3020 nM
For compound 4 the middle estimate is 1.5-fold (0.17 log units) above the measured one; the range from low to high includes it.
By their numbers in this assay, from the lowest: compound 2; then compounds 1 and 4 (each within the scatter of the next); then compound 3.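

In this assay, trifluoromethoxy in place of fluoro gives a 2.4-fold lower number from compound 3 to compound 4 (0.38 log units; beyond the scatter). This shows that the aromatic carbon para to a large group tolerates a group of five heavy atoms, and that a second swap here, on a core carrying a different halogen, also moves the number down beyond the scatter. Nothing available explains this step.

As far as these compounds go, whether an amine or a carboxylic acid at this place would lower the number further remains open. So does whether trifluoromethoxy would give a similar step on the core of compound 1.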